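This account rests on a few compounds, and the source may have more. Where it says the series, first, only, none or still open, it means among the compounds named here.

Going by the values given here, in an assay on HeLa cells for displacement of a labelled ligand from 5-hydroxytryptamine receptor 6 (Homo sapiens) (on this read-out higher numbers stand for weaker inhibition and lower numbers for stronger inhibition), compound 1 `O=S(=O)(c1ccccc1Cl)c1cn(C2CCCNC2)c2ncccc12` gives 3.7 nM, and compound 2 `O=S(=O)(c1ccc(Cl)cc1)c1cn(C2CCCNC2)c2ncccc12` gives 7.6 nM, the higher of the two numbers, the only measured step being a 2.1-fold higher number from compound 1 to compound 2 (0.31 log units; beyond the scatter). Compound 3 `O=S(=O)(c1cccc(Br)c1)c1cn(C2CCCNC2)c2ncccc12` differs from compound 2 by 3-bromophenyl in place of 4-chlorophenyl on a sulfonyl sulfur. Among the compounds with values here, the one measured step, from compound 1 to compound 2, moves a chlorine around the same ring and is modest in size; no measured step touches a bromine or this position. The expected step is therefore small, a 1.5-fold lower number from compound 2 to compound 3 (0.18 log units; within the scatter), and compound 3 is estimated at 5 nM, within 2 nM to 13 nM.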

Compound 3, inhibition constant: 3.8 nM
Beside the measured number, compound 3's estimate is 1.3-fold (0.12 log units) above it; the measured number falls inside the stated range.
By their numbers in this assay, from the lowest: compounds 1, 3 and 2 (each within the scatter of the next, the first and the last beyond it).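

Changing to 3-bromophenyl gives a 2.0-fold lower number from compound 2 to compound 3 (0.30 log units; within the scatter) and a 1.0-fold higher number from compound 1 to compound 3 (0.01 log units; within the scatter) in this assay, so this group cannot be told apart from either chlorophenyl, even though those two differ from each other beyond the scatter. The ring on the sulfonyl sulfur therefore accepts a bromine as well as a chlorine, but the halogen and its place on the ring change together here, so their contributions cannot be separated. Nothing available explains these numbers. A 3-chlorophenyl group would separate the halogen from its place on the ring. As far as these compounds go, it also remains open how a methoxy group or a nitrile on this ring would read.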